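The source may hold more compounds than are shown below. What is called first, only, known or untested is meant among the compounds shown, and "the series" means these compounds.

Measured compounds:
compound 1, `Cc1ccc(-n2nc(C(C)(C)C)cc2NC(=O)Nc2cc(-c3ccc4nccnc4c3)[nH]n2)cc1`, 62 nM
compound 2, `COc1ccc(-c2cc(NC(=O)Nc3cc(C(C)(C)C)nn3-c3ccc(C)cc3)n[nH]2)nc1`, 607 nM

Compound 1 gives the lowest of the two numbers in an assay on NIH3T3 cells for inhibition of protein-tyrosine kinase 2-beta (Mus musculus) (on this read-out higher numbers stand for weaker inhibition and lower numbers for stronger inhibition), and its nearest neighbour is compound 2 at a 9.8-fold higher number from compound 1 to compound 2 (0.99 log units; beyond the scatter), a step beyond the scatter. Compound 3, `COc1ccc(-c2cc(NC(=O)Nc3cc(C(C)(C)C)nn3-c3ccc(C)cc3)n[nH]2)cn1`, has not yet been measured in this assay. It differs from compound 1 in one place: 6-methoxypyridin-3-yl in place of quinoxalin-6-yl on an aromatic carbon.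

Going by the values given here, the only measured step that bears on this change is the one from compound 1 to compound 2, where a methoxypyridyl group likewise took the place of the quinoxalin-6-yl group and the number rose by a 9.8-fold higher number from compound 1 to compound 2 (0.99 log units; beyond the scatter). Among the compounds with values here, the group entering compound 3 is a regioisomer of the one in compound 2, so the same direction is expected, though its size is uncertain with a single precedent. On that basis compound 3 is expected to give a weaker inhibition than compound 1, with an estimated step of a 6.5-fold higher number from compound 1 to compound 3 (0.81 log units; beyond the scatter). The estimate for compound 3 in this assay is 400 nM, within a range from 120 nM to 1300 nM.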

Compound 3, half-maximal inhibitory concentration in the protein-tyrosine kinase 2-beta assay: 524 nM
Beside the measured number, compound 3's estimate is 1.3-fold (0.12 log units) below it, within the range that was stated.
By their numbers in the protein-tyrosine kinase 2-beta assay, from the lowest: compound 1; then compounds 3 and 2 (each within the scatter of the next).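

Going by these compounds alone, in the protein-tyrosine kinase 2-beta assay compound 3, with a second methoxypyridyl group at this position, gives 524 nM with an 8.5-fold higher number from compound 1 to compound 3 (0.93 log units; beyond the scatter) and so shows that the gap from quinoxalin-6-yl is not confined to the single methoxypyridyl group seen earlier. On the protein-tyrosine kinase 2-beta assay the exchange of 5-methoxypyridin-2-yl for 6-methoxypyridin-3-yl shows a 1.2-fold lower number from compound 2 to compound 3 (0.06 log units; within the scatter) and leaves these two groups without an order at this position, on an aromatic carbon of the five-membered ring. In a physicochemical assay for lipophilicity, at pH 7.4 (a lower number here means a more polar compound, a higher number a more lipophilic compound), compound 1 gives 4.7 and compound 3 gives 4.9 and the exchange of quinoxalin-6-yl for 6-methoxypyridin-3-yl shows a number 0.20 log units higher from compound 1 to compound 3 (within the scatter) and places the two compounds within the scatter on that read-out, whereas they stand well apart on the protein-tyrosine kinase 2-beta assay.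

The compounds shown leave open whether the step follows the second ring of quinoxalin-6-yl or the methoxy group, and how a plain pyridinyl, or a pyridine bearing a dimethylamino or morpholine group in place of methoxy, would stand at this position. Nothing reported here accounts for the step from quinoxalin-6-yl to either methoxypyridyl group.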